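The compounds below may be only part of what the source reports. "The series", "measured", "known", "first", "only" and "open" are said of these compounds alone.

In an ADME assay on cells (Epithelial cell, Homo sapiens) for antiproliferative activity, read by MTT assay, with a stated time of 48 h (on this read-out higher numbers stand for weaker inhibition and lower numbers for stronger inhibition), compound 1 `COC(=O)/C(=C/c1ccccc1)CN1C(=O)[C@@H](OC)[C@H]1c1ccc(Cl)cc1` gives 37900 nM as its reading. Compound 2 `COC(=O)/C(=C/c1ccccc1)CN1C(=O)[C@@H](OC)[C@H]1c1ccccc1` is reported only as "not toxic" (no number reported) and so has no single number to stand on. Among the measured compounds shown here, the one structural change in compound 3 `COC(=O)/C(=C/c1ccccc1)CN1C(=O)[C@@H](OC)[C@H]1c1cccc([N+](=O)[O-])c1` is nitro in place of hydrogen on an aromatic carbon and amounts to nitro in place of hydrogen on an aromatic carbon. For the measured compounds named here, no measured step covers this change, so only a modest move toward stronger inhibition than compound 2 is expected in this assay and the sole numerical guide is compound 1 at 37900 nM in the same series. The estimated value for compound 3 is 35000 nM with an expected range from 9000 nM to 120000 nM for now.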

Compound 3, half-maximal inhibitory concentration: "not toxic" (no number reported)
For compound 3 the study gives words and no number, and the estimate cannot be compared.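

Compound 2 and compound 3 are both reported only in words, as not toxic, so no step can be read between them. From the compounds shown here alone, whether nitro in place of hydrogen shifts the reading at all remains open. Nothing available bears on this result.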